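Chloro for fluoro on the shared core

The source may hold more compounds than are shown below. What is called first, only, known or untested is meant among the compounds shown, and "the series" means these compounds.

Compound 1, `Brc1ccc(NC2=NCCC3(CCCCC3)S2)cc1`: 2.53
Compound 2, `Fc1ccc(NC2=NCCC3(CCCCC3)S2)cc1Cl`: 2.03

Of the compounds shown here, two on a shared core have been measured in a physicochemical assay for lipophilicity, measured as octanol-water partition, at pH 7.4; on this read-out lower numbers stand for lower lipophilicity and higher numbers for higher lipophilicity. Compound 2 stands lowest of the two numbers; its nearest neighbour, compound 1, gives 2.53, a number higher by more than the scatter. Compound 3, `Clc1ccc(NC2=NCCC3(CCCCC3)S2)cc1Cl`, has not yet been measured in this assay. It differs from compound 2 in one place: chloro in place of fluoro on an aromatic carbon. For the measured compounds named here, no step between measured compounds mirrors this change, so the expectation rests on the change alone. Compound 3 is expected to give a higher number than compound 2, by an estimated a number 0.57 log units higher from compound 2 to compound 3 (beyond the scatter), beyond the scatter. The estimate for compound 3 is 2.6, within 2.2 to 3.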

Compound 3, distribution coefficient: 2.45
The estimate for compound 3 lay 0.15 log units above the measured number, within the range that was stated.
By their numbers in this assay, from the lowest: compound 2; then compounds 3 and 1 (each within the scatter of the next).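

In this assay, chloro in place of fluoro on this aromatic carbon, ortho to a chloro group and para to a large group, gives a number 0.42 log units higher from compound 2 to compound 3 (beyond the scatter) and is a modest change. For the compounds shown here, the earlier compounds differ in more than one place, so this is the first step that isolates this position and this change. No measured information accounts for the size of the step. As far as these compounds go, whether a methyl or methoxy group here would give a number near either halogen stays open. So does whether the same change gives a similar step without the chloro group ortho to it.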